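The compounds below may be only part of what the source reports. "The series", "measured", "known", "first", "only" and "open" are said of these compounds alone.

Measured so far:
- compound 1 `CN1CCN(c2cn(S(=O)(=O)c3ccccc3)c3ccccc23)CC1`: 4 nM
- compound 2 `O=S(=O)(c1ccccc1)n1cc(N2CCCCC2)c2ccccc21`: 219 nM

In an assay on isolated protein for displacement of a labelled ligand from 5-hydroxytryptamine receptor 6 (Homo sapiens), read by scintillation counting, with a stated time of 1 h (a lower number here means a stronger inhibitor, a higher number a weaker inhibitor), compound 1 gives 4 nM and compound 2 gives 219 nM. Compound 2 stands at the highest number of the two measured compounds, and its nearest neighbour is compound 1, which differs only in the group on the aromatic carbon. That single change, piperidin-1-yl in place of 4-methylpiperazin-1-yl, produced a 55-fold higher number from compound 1 to compound 2 (1.74 log units; beyond the scatter).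

Compound 3 `CN(C)c1cn(S(=O)(=O)c2ccccc2)c2ccccc12` has not yet been measured in this assay. It differs from compound 2 by dimethylamino in place of piperidin-1-yl on an aromatic carbon. Going by the values given here, the one measured step bears on compound 3 only loosely, since it swapped one ring for another ring at the same carbon, while here the ring is removed and a smaller group takes its place. Among the compounds with values here, no measured pair shows what that does, so the expectation is an essentially flat step, with a wide range to either side, expected as a 1.4-fold higher number from compound 2 to compound 3 (0.14 log units; within the scatter). Compound 3 is therefore estimated at 300 nM, expected to lie between 80 nM and 1200 nM.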

Compound 3, inhibition constant: 474 nM
The estimate for compound 3 lay 1.6-fold (0.20 log units) below the measured number; the range from low to high includes it.
By their numbers in this assay, from the lowest: compound 1; then compound 2; then compound 3.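

In this assay, removing the ring at this aromatic carbon and replacing piperidin-1-yl with dimethylamino gives a 2.2-fold higher number from compound 2 to compound 3 (0.34 log units; beyond the scatter), which is only a modest step even though the group falls from 6 heavy atoms to 3 and no longer contains a ring. Replacing 4-methylpiperazin-1-yl with the same dimethylamino gives a far larger change, a 120-fold higher number from compound 1 to compound 3 (2.07 log units; beyond the scatter), so at this position both groups that replace 4-methylpiperazin-1-yl sit well above compound 1 but fairly close to each other. Among these three compounds, then, simply having a ring at this carbon counts for little, and the strong result belongs to 4-methylpiperazin-1-yl in particular.

Nothing available here explains why this group stands apart from the other two. As far as these compounds go, it also remains open which part of 4-methylpiperazin-1-yl matters, a question that piperazin-1-yl, without the methyl, and morpholin-4-yl, with an oxygen in place of the methyl-bearing nitrogen, could help to separate.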